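A few compounds are considered here, and "the series" means these few. Any claim that something is new, unique, unknown or untested is made for them only; others in the source may bear on it.

Among the three measured compounds, compound 3 `Cn1ccc2cc(-c3ccc4oc(Nc5cccnc5)nc4c3)ccc21` gives 226 nM in an assay on HEK293 cells for inhibition of Fatty-acid amide hydrolase 1 (Homo sapiens), read by fluorescence (a higher number here means a weaker inhibitor, a lower number a stronger inhibitor), the second highest of the three numbers: compound 1 `Cn1ccc2cc(-c3ccc4oc(NC5CCCCC5)nc4c3)ccc21` stands nearest with 911 nM, and compound 2 `Cn1ccc2cc(-c3ccc4oc(Nc5ccccc5)nc4c3)ccc21` furthest with 48 nM. The step of a 4.0-fold lower number from compound 1 to compound 3 (0.61 log units; beyond the scatter) and the step of a 4.7-fold higher number from compound 2 to compound 3 (0.67 log units; beyond the scatter) place compound 3 between the other two, both gaps beyond the scatter.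

Compound 4 `CNc1nc2cc(-c3ccc4c(ccn4C)c3)ccc2o1` has not been measured; it differs from compound 3 in one place: methyl in place of pyridin-3-yl on a nitrogen on an aromatic ring. Going by the values given here, no measured pair shows this exact change. Among the compounds with values here, the steps that bear on it concern the same nitrogen: a 19-fold lower number from compound 1 to compound 2 (1.28 log units; beyond the scatter) and a 4.0-fold lower number from compound 1 to compound 3 (0.61 log units; beyond the scatter) both show a six-membered aromatic ring on that nitrogen giving a lower number than cyclohexyl, while a 4.7-fold higher number from compound 2 to compound 3 (0.67 log units; beyond the scatter) shows the ring with one nitrogen giving a higher number than phenyl. Compound 4 carries no ring at all on that nitrogen, only a methyl, so a higher number than compound 3 is expected in this assay, probably also higher than that of compound 1 at 911 nM. The estimate for compound 4 is 3000 nM, with a range from 700 nM to 12000 nM, which is an expected step of a 13-fold higher number from compound 3 to compound 4 (1.12 log units; beyond the scatter).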

Compound 4, half-maximal inhibitory concentration: > 1000 nM
Compound 4 ended at the assay's limit (the forecaster's own chance of this, stated with the estimate: 10%); the middle value lies beyond the limit too.
By their numbers in this assay, from the lowest: compound 2; then compound 3; then compound 1. At a limit, above all of these: compound 4.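

In this assay compound 4 stands at a limit of the assay and not at a number: the limit of > 1000 nM in this assay, at which 1 of the 4 values shown sits. Taking the ring off the nitrogen and leaving only methyl gives an at least 4.4-fold higher number from compound 3 to compound 4 (0.64 log units; beyond the scatter), an at least 20-fold higher number from compound 2 to compound 4 (1.31 log units; beyond the scatter) and an at least 1.0-fold higher number from compound 1 to compound 4 (0.04 log units; that floor lies within the scatter), so both aromatic groups on this nitrogen, pyridin-3-yl and phenyl, give lower numbers than methyl, and all three steps are floors whose full size stays unknown. The floor of the step from cyclohexyl to methyl lies within the scatter, so the series does not show whether methyl differs from cyclohexyl at this position, and only the two aromatic groups are clearly set apart from methyl.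

The compounds shown leave open whether a ring on this nitrogen is needed at all or whether the heavy atoms alone count, a question that a longer chain such as n-hexyl, or a benzyl group, would address. They also leave open how far phenyl itself can be taken, for instance with a methoxy group or a carboxylic acid on the ring.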